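The compounds below may be only part of what the source reports. "The series", "measured", "known", "first", "only" and "open" are said of these compounds alone.

Measured in a functional assay on RKE cells for antagonist activity at Vasoactive intestinal polypeptide receptor 1 (Rattus norvegicus), read by HTRF and cAMP accumulation, with stated times of 10 min and 30 min; on this read-out lower numbers stand for stronger inhibition and higher numbers for weaker inhibition:
compound 1 `CC(C)c1cc(C(C)(C)C)cc(-c2ccc(F)cc2)c1CO` gives 740 nM
compound 2 `Cc1ccccc1-c1cc(C(C)(C)C)cc(C(C)C)c1CO` gives > 50000 nM, a limit of the assay and not a number
compound 3 `Cc1cccc(-c2cc(C(C)(C)C)cc(C(C)C)c2CO)c1` gives 240 nM

Compound 3 holds the lowest of the two numbers shown; the nearest number is a 3.1-fold lower number from compound 1 to compound 3 (0.49 log units; beyond the scatter). Compound 4 `CC(C)c1cc(C(C)(C)C)cc(-c2cccc(Cl)c2)c1CO` differs from compound 3 by chloro in place of methyl on an aromatic carbon. Among the compounds with values here, no measured step exchanges a methyl for a chloro on this ring. Within the data shown here, the recorded steps move between different methylphenyl and fluorophenyl groups (an at least 67-fold higher number from compound 1 to compound 2 (1.82 log units; beyond the scatter); an at least 200-fold lower number from compound 2 to compound 3 (2.31 log units; beyond the scatter)), which is not the change made here, so they give no close precedent. The expected step of a 1.3-fold higher number from compound 3 to compound 4 (0.10 log units; within the scatter) in this assay is therefore no larger than the usual scatter, in either direction. The estimate for compound 4 in this assay is 300 nM, with a range from 100 nM to 900 nM.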

Compound 4, half-maximal inhibitory concentration: 100 nM
Estimate against measurement, compound 4: 3.0-fold (0.48 log units) above; the measured number falls inside the stated range.
By their numbers in this assay, from the lowest: compound 4; then compound 3; then compound 1. At a limit, above all of these: compound 2.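

In this assay, chloro in place of methyl on this aromatic carbon, meta to a large group, gives a direct read on this exchange: a 2.4-fold lower number from compound 3 to compound 4 (0.38 log units; beyond the scatter). Against the other aryl groups, 3-chlorophenyl gives a 7.4-fold lower number from compound 1 to compound 4 (0.87 log units; beyond the scatter), and an at least 500-fold lower number from compound 2 to compound 4 (2.69 log units; beyond the scatter). Compound 2 stands at a limit and not a number, so the last step is only a bound: the limit of > 50000 nM in this assay, at which 1 of the 4 values shown sits.

Still open, on these data alone, is how a bromo, a methoxy or an amine on this same carbon would compare with chloro. The compounds shown also do not tell whether chloro elsewhere on this ring would hold the number of compound 4.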